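A few compounds are considered here, and "the series" means these few. Any claim that something is new, unique, unknown or untested is made for them only; others in the source may bear on it.

In a functional assay on RXF 393 cells (Homo sapiens) for inhibition (on this read-out lower numbers stand for stronger inhibition of growth and higher numbers for weaker inhibition of growth), compound 1 `COc1cc(/C=C/C(=O)c2cccc(-n3cc(-c4ccccc4)[nH]c3=O)c2)ccc1O` gives 2270 nM, compound 2 `O=C(/C=C/c1cccc(O)c1)c1cccc(-n2cc(-c3ccccc3)[nH]c2=O)c1` gives 1890 nM and compound 3 `O=C(/C=C/c1cccc(O)c1)c1cccc(-n2cc(-c3ccc(Cl)cc3)[nH]c2=O)c1` gives 1510 nM, so compound 3 stands within the scatter of both others. Compound 4 `COc1cc(/C=C/C(=O)c2cccc(-n3cc(-c4ccc(Cl)cc4)[nH]c3=O)c2)ccc1O` has not been measured. It differs from compound 3 by 4-hydroxy-3-methoxyphenyl in place of 3-hydroxyphenyl on a double-bonded chain carbon bound to a double-bonded chain carbon, with 4-hydroxy-3-methoxyphenyl in place of 3-hydroxyphenyl on a double-bonded chain carbon bound to a double-bonded chain carbon. The same swap, in the opposite direction and with hydrogen instead of chloro on the aromatic carbon, gave a 1.2-fold lower number from compound 1 to compound 2 (0.08 log units; within the scatter). Adding that chloro gave a 1.3-fold lower number from compound 2 to compound 3 (0.10 log units; within the scatter). No change beyond the scatter is therefore expected in this assay, and the expected step is a 1.2-fold higher number from compound 3 to compound 4 (0.08 log units; within the scatter). Compound 4 is estimated at 1800 nM, with an expected range from 1100 nM to 3000 nM.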

Compound 4, concentration for 50% growth inhibition: 6400 nM
The estimate for compound 4 lay 3.6-fold (0.55 log units) below the measured number; the measured number lies above the stated range.
By their numbers in this assay, from the lowest: compounds 3, 2 and 1 (each within the scatter of the next); then compound 4.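

On compounds bearing the chloro, 4-hydroxy-3-methoxyphenyl in place of 3-hydroxyphenyl gives a 4.2-fold higher number from compound 3 to compound 4 (0.63 log units; beyond the scatter) in this assay, so this swap does not carry over unchanged from the compounds without chloro: the same change on two cores in this assay, a 1.2-fold lower number (0.08 log units; within the scatter) from compound 1 to compound 2 and a 4.2-fold lower number (0.63 log units; beyond the scatter) from compound 4 to compound 3, 3.5-fold (0.55 log units) apart, beyond the scatter of two such steps

The chloro depends on its partner in the same way, giving a 2.8-fold higher number from compound 1 to compound 4 (0.45 log units; beyond the scatter) when 4-hydroxy-3-methoxyphenyl is present: the same change on two cores in this assay, a 1.3-fold lower number (0.10 log units; within the scatter) from compound 2 to compound 3 and a 2.8-fold higher number (0.45 log units; beyond the scatter) from compound 1 to compound 4, 3.5-fold (0.55 log units) apart, beyond the scatter of two such steps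

The two changes therefore do not simply add up at this position.

Still open, on these data alone, is which part of the 4-hydroxy-3-methoxyphenyl group matters, the methoxy or the place of the hydroxy. As far as these compounds go, it is also open whether a fluoro or a methyl in place of the chloro would pair with it in the same way.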